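Swapping a Cyclohexyl for a Butenyl Chain

The compounds below may be only part of what the source reports. "The series", "measured", "known", "first", "only" and "open" are said of these compounds alone.

The compounds measured so far:
Compound 1 `C[C@H]1CC(Cl)=C[C@@H](C2CCCCC2)O1`, 79000 nM
Compound 2 `CC[C@H]1CC(Cl)=C([Si](C)(C)C)[C@@H](C2CCCCC2)O1`, 75000 nM
Compound 3 `C[C@@H]1O[C@H](C2CCCCC2)C([Si](C)(C)C)=C(Cl)[C@H]1C`, 77000 nM

In a functional assay on A2780 cells (Homo sapiens) for antiproliferative activity (on this read-out higher numbers stand for lower toxicity in this test and lower numbers for higher toxicity in this test), compound 3 gives 77000 nM. The values of compound 1 and compound 2 in this assay sit within the scatter of that number, so the three compounds cannot be told apart on this read-out.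

Compound 4 `C=CCC[C@H]1O[C@@H](C)[C@H](C)C(Cl)=C1[Si](C)(C)C` is not yet measured. Compared with compound 3, the change is but-3-en-1-yl in place of cyclohexyl on a saturated ring carbon. Nothing in the three measured compounds shows how a change of this kind moves the read-out. Since all three measured compounds give values within the scatter of one another, compound 4 is expected to show a step of a 1.0-fold higher number from compound 3 to compound 4 (0.02 log units; within the scatter), that is, no change beyond the scatter. For compound 4 the estimate in this assay is 80000 nM, with a range from 40000 nM to 160000 nM.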

Compound 4, concentration lethal to 50% of the cells: 19000 nM
For compound 4 the middle estimate is 4.2-fold (0.62 log units) above the measured one, and the stated range ends above it.
By their numbers in this assay, from the lowest: compound 4; then compounds 2, 3 and 1 (each within the scatter of the next).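

In this assay the exchange of cyclohexyl for but-3-en-1-yl on the saturated ring carbon next to the ring oxygen gives a 4.1-fold lower number from compound 3 to compound 4 (0.61 log units; beyond the scatter). Among the compounds shown here, this is the first sign that the group at this position can move the read-out, with the open chain going with higher toxicity in this test. Nothing measured here gives a reason for the step.

Still open, as far as these compounds go, is whether the step goes with losing the ring, having fewer heavy atoms or gaining the double bond. A saturated butyl chain or a longer chain ending in a double bond at this carbon would help separate these.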